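The source may hold more compounds than are shown below. What is called first, only, known or untested is meant among the compounds shown, and "the series" means these compounds.

Measured in an ADME assay on a cell-free system (plasma, Homo sapiens) for metabolic stability, read by LC-MS; a higher number here means that the compound lasts longer, a lower number that the compound disappears faster:
- compound 1 (`CCCCCCOC(=O)c1cccc(-c2cc(C(=O)Nc3ccncc3)ccc2CN)c1`): 0.833 h
- compound 2 (`NCc1ccc(C(=O)Nc2ccncc2)cc1-c1cccc(C(=O)OCC2CCCCC2)c1`): 1.65 h

Compound 2 stands within the scatter of compound 1. Compound 3 (`NCc1ccc(C(=O)Nc2ccncc2)cc1-c1cccc(C(=O)OCc2ccccc2)c1`) carries phenyl in place of cyclohexyl on a saturated chain carbon bound to an oxygen next to a carbonyl group. For the measured compounds named here, the only measured step at this place, a 2.0-fold higher number from compound 1 to compound 2 (0.30 log units; within the scatter), stays within the scatter, and it involved no phenyl group, so it is a weak guide. A change beyond the scatter in this assay is therefore not expected, and no firm direction can be given. The expected step is a 1.4-fold lower number from compound 2 to compound 3 (0.14 log units; within the scatter). For compound 3 the estimate is 1.2 h, with an expected range of 0.5 h to 2.8 h.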

Compound 3, half-life: 1.07 h
The estimate for compound 3 lay 1.1-fold (0.05 log units) above the measured number, within the range that was stated.
By their numbers in this assay, from the lowest: compounds 1, 3 and 2 (each within the scatter of the next).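

In this assay, phenyl in place of cyclohexyl at this place gives a 1.5-fold lower number from compound 2 to compound 3 (0.19 log units; within the scatter), and phenyl in place of pentyl gives a 1.3-fold higher number from compound 1 to compound 3 (0.11 log units; within the scatter). For the compounds shown here, an aromatic ring on this chain carbon, absent from the earlier compounds, thus leaves all three compounds within the scatter of one another. Nothing available explains these numbers. The compounds shown leave open whether an amine, a carboxylic acid or a longer chain at this place would move the number beyond the scatter.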